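Swapping the Amide Aryl Group in a Chalcone Series

The compounds below may be only part of what the source reports. "The series", "measured", "known", "first", "only" and "open" are said of these compounds alone.

Measured compounds:
- compound 1, `O=C(Nc1cccc(/C=C/C(=O)c2nc3ccccc3[nH]2)c1)c1ccc(Cl)cc1`, 8410 nM
- compound 2, `O=C(Nc1cccc(/C=C/C(=O)c2nc3ccccc3[nH]2)c1)c1cccc(Br)c1`, 5210 nM
- compound 3, `O=C(Nc1cccc(/C=C/C(=O)c2nc3ccccc3[nH]2)c1)c1ccc(Br)cc1`, 7000 nM

All three share one core and differ only in the aryl group attached to the amide carbonyl. In a functional assay on MCF7 cells (Homo sapiens) for antiproliferative activity, read by MTT assay, with a stated time of 48 h (a higher number here means a weaker inhibitor, a lower number a stronger inhibitor), compound 3 gives 7000 nM, the second highest of the three numbers; its neighbour compound 1 gives 8410 nM, and compound 2 gives 5210 nM. Every step among these three is within the scatter: a 1.6-fold lower number from compound 1 to compound 2 (0.21 log units; within the scatter), a 1.2-fold lower number from compound 1 to compound 3 (0.08 log units; within the scatter), and a 1.3-fold higher number from compound 2 to compound 3 (0.13 log units; within the scatter).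

Compound 4, `COc1cccc(C(=O)Nc2cccc(/C=C/C(=O)c3nc4ccccc4[nH]3)c2)c1`, has not yet been measured. Its difference from compound 3 is 3-methoxyphenyl in place of 4-bromophenyl on a carbonyl carbon. Going by the values given here, the steps that bear on this are those that also move a group from one position of this ring to another or exchange one halogen for another, namely a 1.6-fold lower number from compound 1 to compound 2 (0.21 log units; within the scatter) and a 1.3-fold higher number from compound 2 to compound 3 (0.13 log units; within the scatter); both are small. Among the compounds with values here, the data hold no example of a methoxy group on this ring, so the new group itself is untested. A step of no more than the scatter is therefore expected in this assay, with no clear direction, and the expected step is a 1.2-fold lower number from compound 3 to compound 4 (0.07 log units; within the scatter). For compound 4 the estimate is 6000 nM, within a range of 2500 nM to 15000 nM.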

Compound 4, half-maximal inhibitory concentration: 17800 nM
Compound 4: the middle estimate sits 3.0-fold (0.47 log units) below what was measured; the whole stated range lies below it.
By their numbers in this assay, from the lowest: compounds 2, 3 and 1 (each within the scatter of the next); then compound 4.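

Until now, every change on this aryl group, whether swapping one halogen for another or moving bromo around the ring, stayed within the scatter, so the position could have seemed tolerant of any substituent. The methoxy group ends that impression: in this assay, the number rises against all three halogen compounds (a 2.5-fold higher number from compound 3 to compound 4 (0.41 log units; beyond the scatter); a 2.1-fold higher number from compound 1 to compound 4 (0.33 log units; beyond the scatter)), which makes compound 4 the weakest of the set. The most direct comparison is between the 3-bromophenyl and 3-methoxyphenyl amides, where the group changes but its printed ring position does not (a 3.4-fold higher number from compound 2 to compound 4 (0.53 log units; beyond the scatter)). Nothing available explains why methoxy behaves differently from the halogens.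

Going by these compounds alone, with only one methoxy compound, it remains open whether a 4-methoxyphenyl group would give the same rise, and whether the rise is specific to methoxy or would also appear with a methyl, a hydroxyl or an amine at that place. Going by these compounds, it is also open whether a longer ether chain such as ethoxy, or a carboxylic acid, would push the number further up or bring it back towards the halogen compounds.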